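Trimming the side chain: from benzyloxycarbonyl to hydrogen

The source may hold more compounds than are shown below. What is called first, only, known or untested is meant among the compounds shown, and "the series" means these compounds.

Compound 1 `NC(=O)CC[C@H](NC(=O)CN(c1ncnc2c1ncn2C1CCCCO1)C1CC1)C(=O)OCc1ccccc1`: 22.3%
Compound 2 `O=C(CN(c1ncnc2c1ncn2C1CCCCO1)C1CC1)N[C@@H](CC(=O)OCc1ccccc1)C(=O)OCc1ccccc1`: 7.82%

Within the data shown here, in a functional assay on the whole organism (Tail, strain ICR) with Mus musculus as the target, in the tail flick test, with a stated time of 120 min, at a dose of 25 umol/kg by the oral route (on this read-out higher numbers stand for a stronger effect at the one dose given and lower numbers for a weaker effect), compound 2 stands lowest of the two numbers measured so far, with compound 1 as its nearest neighbour. Compound 3 `C[C@H](NC(=O)CN(c1ncnc2c1ncn2C1CCCCO1)C1CC1)C(=O)OCc1ccccc1` differs from compound 2 by hydrogen in place of benzyloxycarbonyl on a saturated chain carbon, two bonds along the chain from an amide-type nitrogen and a carbonyl carbon. Among the measured compounds shown here, the one measured step at this position, a number 14.5 percentage points lower from compound 1 to compound 2 (beyond the scatter), shows the benzyloxycarbonyl group accompanied by the lower number; no step removes it entirely. A modest rise is therefore expected, a number 6.2 percentage points higher from compound 2 to compound 3 (within the scatter), but the uncertainty is wide. Compound 3 is estimated at 14%, within a range from 4% to 28%.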

Compound 3, a percentage reported as activity, at one dose (the size of the read-out at that dose, not a potency): 25.3%
Estimate against measurement, compound 3: 11.3 percentage points below; measured number inside the range.
By their numbers in this assay, from the lowest: compound 2; then compounds 1 and 3 (each within the scatter of the next).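

Taking benzyloxycarbonyl away entirely gives a number 17.5 percentage points higher from compound 2 to compound 3 (beyond the scatter) in this assay, so the full cut to hydrogen carries no loss of effect at this place on the saturated chain carbon. Replacing carbamoylmethyl with hydrogen gives a number 3 percentage points higher from compound 1 to compound 3 (within the scatter), so this group and hydrogen cannot be told apart on this read-out, and only benzyloxycarbonyl stands out with a lower number. Nothing available explains either step. On these data alone, whether an amine, a carboxylic acid or a longer alkyl chain at this place would read differently from hydrogen remains open.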